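This account rests on a few compounds, and the source may have more. Where it says the series, first, only, none or still open, it means among the compounds named here.

Measured in an assay on HEK-293T cells for inhibition of diacylglycerol lipase-alpha (Homo sapiens), read by colorimetric assay (a lower number here means a stronger inhibitor, a higher number a weaker inhibitor), so far:
- compound 1, `Cn1nnc(C(=O)CCCCCCc2ccccc2)n1`: compound 1 gives > 10000 nM, which is a limit of the assay.
- compound 2, `O=C(CCCCCCc1ccccc1)c1nc(Cl)co1`: compound 2 gives 2400 nM.
- compound 3, `CSc1cnc(C(=O)CCCCCCc2ccccc2)o1`: compound 3 gives > 10000 nM, which is a limit of the assay.

Within the data shown here, compound 2 is the only member of the series with a number; the other two sit at the limit of > 10000 nM in this assay, at which 2 of the 3 values shown sit. Both measured steps touch the heteroaryl on the carbonyl carbon: an at least 4.1-fold lower number from compound 1 to compound 2 (0.61 log units; beyond the scatter), and an at least 4.1-fold higher number from compound 2 to compound 3 (0.61 log units; beyond the scatter). Compound 4, `O=C(CCCCCCc1ccccc1)c1nc(-c2ccccc2)co1`, is not yet measured. It differs from compound 2 by phenyl in place of chloro on an aromatic carbon, on the aromatic carbon of the five-membered ring with one nitrogen and one oxygen.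

The two measured steps show that changes at this ring move this assay beyond the scatter, with compound 2 standing alone with a number. Whether phenyl in place of chloro moves the number up or down cannot be read from them. Compound 4 is therefore expected to give around 4000 nM, with a range of 800 nM to 20000 nM. The expected step is a 1.7-fold higher number from compound 2 to compound 4 (0.22 log units; within the scatter), an estimate with wide uncertainty in either direction.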

Compound 4, half-maximal inhibitory concentration: 8710 nM
Beside the measured number, compound 4's estimate is 2.2-fold (0.34 log units) below it, and the stated range covers the measured number.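

In this assay, among these compounds, with the ring of compound 2 kept, phenyl in place of chloro on the aromatic carbon next to the ring nitrogen gives a 3.6-fold higher number from compound 2 to compound 4 (0.56 log units; beyond the scatter), the first reading of a change at this carbon alone. Chloro is thus favoured over phenyl here, although the earlier steps had changed only the heteroaryl on the carbonyl carbon. Even with six heavy atoms in place of one, compound 4 keeps a measurable number and does not join the limit: the limit of > 10000 nM in this assay, at which 2 of the 4 values shown sit.

With only chloro and phenyl shown at this carbon, how methyl, methoxy or an amine would read there remains open, as does the effect of a longer chain between carbonyl and phenyl. The step between the two limit values cannot be read.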